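The compounds below may be only part of what the source reports. "The series", "measured", "known", "first", "only" and "open" are said of these compounds alone.

Measured in a functional assay on U-937 cells (Homo sapiens) for inhibition, read by scintillation counting, with a stated time of 15 min; a higher number here means a weaker inhibitor, a lower number a stronger inhibitor:
- compound 1 `COc1ccc(-c2cn(Cc3ccc(F)cc3)c(=O)c(C(=O)NC3CCCCCC3)c2C)cc1`: 280 nM
- compound 2 `COc1ccc(-c2c(Br)cn(Cc3ccc(F)cc3)c(=O)c2C(=O)NC2CCCCCC2)cc1`: > 10000 nM (a limit)

Compound 2 gives no number in this assay, only the limit > 10000 nM. On these data alone, this puts it at the same end of the assay as the limit of > 10000 nM in this assay, at which 1 of the 2 values shown sits, so its true position is unknown. Compound 1, at 280 nM, shows that the assay can return a number for a compound carrying the same cycloheptylcarbamoyl and 4-fluorobenzyl groups.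

Compound 3 `Cc1c(Br)cn(Cc2ccc(F)cc2)c(=O)c1C(=O)NC1CCCCCC1` keeps the bromo group of compound 2 but has methyl in place of 4-methoxyphenyl on an aromatic carbon, opposite the ring nitrogen: methyl in place of 4-methoxyphenyl on an aromatic carbon. Among the compounds with values here, no measured pair isolates this change, so its size cannot be read from the data. The expectation rests only on two measurements. One is the reading of compound 1 at 280 nM. The other is the limit held by compound 2. A clear move toward stronger inhibition is expected, and the estimated move is an at least 6.6-fold lower number from compound 2 to compound 3 (0.82 log units; beyond the scatter), though compound 3 could still stay at the limit. For compound 3 the expected value in this assay is 1500 nM, with an estimated range from 150 nM to 10000 nM.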

Compound 3, half-maximal inhibitory concentration: 930 nM
Compound 3: the middle estimate sits 1.6-fold (0.21 log units) above what was measured; low and high end bracket the measured number.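

In this assay, methyl in place of 4-methoxyphenyl on the aromatic carbon opposite the ring nitrogen, with the bromo group kept, gives an at least 10-fold lower number from compound 2 to compound 3 (1.03 log units; beyond the scatter), so a measurable reading with bromo present does not need the 4-methoxyphenyl group at this carbon. On these data alone, the true size of this step stays unknown, since compound 2 holds a limit of the assay and not a number: the limit of > 10000 nM in this assay, at which 1 of the 3 values shown sits. Against compound 1, bromo in place of 4-methoxyphenyl gives a 3.3-fold higher number from compound 1 to compound 3 (0.52 log units; beyond the scatter), a modest step that is smaller than the one from the limit, so compound 3 stays within reach of compound 1 with no 4-methoxyphenyl group at all.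

Still open, as far as these compounds go, is whether the gain belongs to methyl itself or simply to the departure of 4-methoxyphenyl, a question that hydrogen, an ethyl group or an unsubstituted phenyl at this carbon would help to settle. Also open, from the compounds shown here alone, is whether the reading depends on bromo, which a chloro group or a nitrile in its place, with methyl kept, would test.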